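The source may hold more compounds than are shown below. What is called first, only, known or untested is meant among the compounds shown, and "the series" means these compounds.

Measured so far in an assay on membranes from HEK293 cells for displacement of a labelled ligand from adenosine receptor A2b (Homo sapiens), read by scintillation counting, with a stated time of 30 min, tested at 1 uM; on this read-out lower numbers stand for less inhibition and higher numbers for more inhibition at the one concentration tested (going by the name of the read-out):

Compound 1 `CCCC(=O)C1=C(C)NC(=O)NC1c1ccsc1`: 9%
Compound 2 `CC1=C(C(=O)NC(C)C)C(c2ccoc2)NC(=O)N1`: 3%

Compound 2 has the lower of the two numbers, but its gap to compound 1 lies within the scatter, so the two readings cannot be told apart. Among the measured compounds shown here, no pair of measured compounds differs in only one place, so no step is known from measurement. Compound 3 `CC1=C(C(=O)NC(C)C)C(c2ccsc2)NC(=O)N1` is not yet measured; it differs from compound 2 by thiophen-3-yl in place of furan-3-yl on a saturated ring carbon. The same kind of exchange is present between compound 1 and compound 2, but those two also differ elsewhere, so their readings show only that both sit low. Compound 3 is therefore expected to sit close to compound 2, with a step of a number 3 percentage points higher from compound 2 to compound 3 (within the scatter) that is expected not to exceed the scatter. For compound 3 the estimate is 6%, with a range from -5% to 17%.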

Compound 3, a percentage reported as inhibition, at one concentration (the size of the read-out at that concentration, not a potency): 3%
Compound 3: the middle estimate sits 3 percentage points above what was measured; the range from low to high includes it.
By their numbers in this assay, from the lowest: compounds 2, 3 and 1 (each within the scatter of the next).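

In this assay, among the compounds shown here, thiophen-3-yl in place of furan-3-yl on the saturated ring carbon gives no change at the digits printed from compound 2 to compound 3 (within the scatter) and so isolates this exchange for the first time, with the isopropylcarbamoyl group held constant. On the carbonyl carbon, isopropylamino in place of propyl gives a number 6 percentage points lower from compound 1 to compound 3 (within the scatter) and so shows that this exchange, also read alone here, cannot be told from the scatter either. Nothing measured here offers an explanation for these readings.

All three compounds sit low at the one concentration tested, so neither place has yet shown a group that moves the reading. As far as these compounds go, whether a phenyl ring on that saturated ring carbon, or a longer chain or a carboxylic acid on the carbonyl carbon, would lift the number beyond the scatter stays open.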